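The source may report more compounds than this note shows. Statements on the series, on what has been measured and on what is new or still open speak of the compounds shown alone.

Three compounds have values in a functional assay on PC-3 cells (Homo sapiens) for cytotoxicity, read by MTT assay, with a stated time of 72 h; on this read-out higher numbers stand for weaker inhibition of growth and lower numbers for stronger inhibition of growth. Compound 1 `CCCOC(=O)Nc1ccc([Se]C#N)cc1` gives 47400 nM in this assay, the second highest of the three numbers; compound 3 `CCCCOC(=O)Nc1ccc([Se][Se]c2ccc(NC(=O)OCCCC)cc2)cc1` gives 52500 nM, and compound 2 `Cc1ccc(OC(=O)Nc2ccc([Se][Se]c3ccc(NC(=O)Oc4ccc(C)cc4)cc3)cc2)cc1` gives 28200 nM, both within the scatter of compound 1, so no order among them can be claimed. Compound 4 `CCOC(=O)Nc1ccc([Se]C#N)cc1` has not been measured in this assay; it differs from compound 1 by one change, (hydrogen in place of methyl on a saturated chain carbon, two bonds along the chain from an oxygen next to a carbonyl group), that is, propyl to ethyl on the carbamate chain. Among the compounds with values here, no step between measured compounds shows the effect of such a change, so no step beyond the scatter is expected. Compound 4 is therefore estimated to give 45000 nM in this assay, between 20000 nM and 100000 nM, the expected step being a 1.1-fold lower number from compound 1 to compound 4 (0.02 log units; within the scatter).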

Compound 4, concentration for total growth inhibition: 39200 nM
For compound 4 the middle estimate is 1.1-fold (0.06 log units) above the measured one; the range from low to high includes it.
By their numbers in this assay, from the lowest: compounds 2, 4, 1 and 3 (each within the scatter of the next).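

In this assay, within the data shown here, the change from propyl to ethyl on the carbamate chain gives the first direct reading at this position (a 1.2-fold lower number from compound 1 to compound 4 (0.08 log units; within the scatter)). Removing this methyl, on a saturated chain carbon, therefore leaves the number within the scatter for this pair. No measurement bears on why this is so.

As far as these compounds go, it remains open whether a longer chain, such as hexyl, would move the number beyond the scatter on the core of compound 1. The same question stands for an amine or a carboxylic acid at the end of the chain.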